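The source may report more compounds than this note shows. Statements on the series, on what has been measured and on what is new or still open speak of the compounds shown alone.

In an assay on cells for inhibition of Amine oxidase [flavin-containing] B (Homo sapiens), read by fluorescence, with stated times of 30 min and 15 min, tested at 1 uM (on this read-out higher numbers stand for more inhibition at the one concentration tested (going by the name of the read-out) and lower numbers for less inhibition), compound 2 `COc1ccc(OCCOc2ccc3[nH]c(=O)n(C(C)C)c3c2)cc1` gives 15.5%, the only number among the compounds shown here, while compound 1 `CC(C)=C1C(=O)Nc2ccc(OCc3ccc(F)cc3)cc21` is recorded in this assay as "not active" (no number reported), without a number. Compound 3 `CCn1c(=O)[nH]c2ccc(OCCOc3ccc(OC)cc3)cc21` differs from compound 2 in one place: hydrogen in place of methyl on a saturated chain carbon bound to an aromatic nitrogen and a saturated chain carbon. For the measured compounds named here, no measured pair shows such a change, so no step can be read from the data. A change of a single carbon is expected to move the result only a little, so the step of a number 3.5 percentage points lower from compound 2 to compound 3 (within the scatter) is expected to stay within the usual scatter. Compound 3 is therefore estimated to give 12%, within a range from 0% to 30%.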

Compound 3, a percentage reported as inhibition, at one concentration (the size of the read-out at that concentration, not a potency): 13.9%
Compound 3: middle estimate off by 1.9 percentage points, on the low side, within the range that was stated.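

In this assay, for the compounds shown here, going from isopropyl to ethyl on the aromatic nitrogen gives a number 1.6 percentage points lower from compound 2 to compound 3 (within the scatter), the first measured step at this position. Removing this one methyl therefore has no effect that can be told apart from ordinary assay variation, at least for this pair. No supporting data bear on why the result came out this way.

The compounds shown leave open whether a longer chain such as butyl would behave the same way at this position. They also leave open the outcome for a chain ending in an amine or a carboxylic acid.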